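Triazole to pyrrole on compound 2

A few compounds are considered here, and "the series" means these few. Any claim that something is new, unique, unknown or untested is made for them only; others in the source may bear on it.

compound 1 `Cc1ccc(OCC(=O)N(Cc2cccs2)c2ccn(C)n2)cc1` — 855 nM
compound 2 `CCN(Cc1c[nH]nn1)C(=O)COc1ccc(C)cc1` — 31100 nM

In an assay on HEK293 cells for agonist activity at transient receptor potential cation channel subfamily M member 8 (Homo sapiens), read by fluorescence and calcium flux, with a stated time of 15 min (on this read-out higher numbers stand for an effect only at larger amounts of compound and lower numbers for an effect already at smaller amounts), compound 2 holds the highest of the two numbers shown; compound 1 lies lower, and that gap is beyond the scatter. Compound 3 `CCN(Cc1cc[nH]c1)C(=O)COc1ccc(C)cc1` carries 1H-pyrrol-3-yl in place of 1H-1,2,3-triazol-4-yl on a saturated chain carbon bound to an amide-type nitrogen. Among the measured compounds shown here, no measured pair shows this change, so the expectation rests on the change alone; the expected step is a 1.6-fold lower number from compound 2 to compound 3 (0.19 log units; within the scatter), a small drift lower that may well stay within the scatter. Compound 3 is accordingly estimated at 20000 nM, with a range from 5000 nM to 80000 nM.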

Compound 3, half-maximal effective concentration: 21800 nM
Compound 3: the middle estimate sits 1.1-fold (0.04 log units) below what was measured, and the stated range covers the measured number.
By their numbers in this assay, from the lowest: compound 1; then compounds 3 and 2 (each within the scatter of the next).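

In this assay, 1H-pyrrol-3-yl in place of 1H-1,2,3-triazol-4-yl on a saturated chain carbon bound to an amide-type nitrogen gives a 1.4-fold lower number from compound 2 to compound 3 (0.15 log units; within the scatter) and so leaves this position insensitive to this change, as far as these two compounds show. The 1H-pyrrol-3-yl group keeps the hydrogen-bond donor but carries no hydrogen-bond acceptors, and the number still stays within the scatter. No measurement at hand gives a reason for this outcome.

Still open, on these data alone, is whether a phenyl ring, a primary amine or a carboxylic acid at this place would move the number beyond the scatter.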